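(4-ethylpiperazin-1-yl)methyl in place of piperidin-1-yl: a cytotoxicity outlook

The compounds below may be only part of what the source reports. "The series", "measured", "known", "first", "only" and "open" are said of these compounds alone.

Compound 1 `COc1ccc(S(=O)(=O)N(CC(N)=O)c2ccc(N(CC(N)=O)S(=O)(=O)c3ccc(NC(C)=O)cc3)c3ccccc23)cc1` was examined in a functional assay on cells (Peritoneal macrophage, Mus musculus) for cytotoxicity, with a stated time of 24 h (a lower number here means that less compound is tolerated, a higher number that more compound is tolerated), where compound 1 gives only a limit, > 50000 nM. Compound 2 `CCCC(=O)Nc1ccc(S(=O)(=O)N(CC(N)=O)c2ccc(N(CC(N)=O)S(=O)(=O)c3ccc(OC)cc3)c3ccccc23)cc1` likewise returns a limit in this assay, > 100000 nM. Compound 3 `COc1ccc(S(=O)(=O)N(CC(N)=O)c2ccc(N(CC(N)=O)S(=O)(=O)c3ccc(NC(=O)CCN4CCCCC4)cc3)c3ccccc23)cc1` also reaches only a limit in this assay, > 100000 nM. Compound 3 thus stands at the same limit as compound 2 (the limit of > 100000 nM in this assay, at which 2 of the 3 values shown sit), while compound 1 sits at a different one (the limit of > 50000 nM in this assay, at which 1 of the 3 values shown sits). These limits leave a step that the two limits leave unreadable from compound 1 to compound 2, a step that the two limits leave unreadable from compound 1 to compound 3 and a step that the two limits leave unreadable from compound 2 to compound 3 without a readable size.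

Compound 4 `CCN1CCN(CCCC(=O)Nc2ccc(S(=O)(=O)N(CC(N)=O)c3ccc(N(CC(N)=O)S(=O)(=O)c4ccc(OC)cc4)c4ccccc34)cc2)CC1` differs from compound 3 by (4-ethylpiperazin-1-yl)methyl in place of piperidin-1-yl on a saturated chain carbon, two bonds along the chain from a carbonyl carbon. For the measured compounds named here, the single measured step at the same place, a step that the two limits leave unreadable from compound 2 to compound 3, offers no readable size, so no movement beyond the scatter is expected in this assay, and the estimated step is a number no higher from compound 3 to compound 4 (the limit leaves the size open). Compound 4 is therefore expected to show 100000 nM in this assay, with an estimated range from 40000 nM to 300000 nM, most probably reported once more as a limit rather than a number.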

Compound 4, half-maximal cytotoxic concentration: > 100000 nM
Compound 4: no number, only a limit; the forecaster's own chance of this, stated with the estimate: 80%; the middle value sits exactly at the limit.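

In this assay compound 4 also reaches only a limit, > 100000 nM, so its steps from compound 1, compound 2 and compound 3 cannot be read. The compounds shown leave open whether any of these side chains changes the tolerated concentration at all.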